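Compound 3 and a pyridin-2-yl amide counterpart

The source may hold more compounds than are shown below. What is called first, only, known or untested is meant among the compounds shown, and "the series" means these compounds.

- compound 1 `O=C(/C=C/c1cccnc1)Nc1ccc(CN2C(=O)c3ccccc3C2=O)cc1` gives "not determined" (no result reported)
- compound 2 `O=C(Nc1ccc(CN2C(=O)c3ccccc3C2=O)cc1)[C@@H]1C[C@H]1c1cccnc1` gives > 2500 nM
- compound 3 `C[C@H](NC(=O)CC(F)(F)F)c1ccc(NC(=O)[C@H]2C[C@@H]2c2cccnc2)cc1` gives 5 nM

Among the measured compounds shown here, in a functional assay on A2780 cells (Homo sapiens) for antiproliferative activity, read by CellTiter-Glo, with a stated time of 4 days (on this read-out lower numbers stand for stronger inhibition and higher numbers for weaker inhibition), compound 3 stands at 5 nM, and this is the only actual number among the three measured compounds. For compound 2 the entry > 2500 nM is a limit and not a number. Compound 1 has no reported result.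

The next compound to be tested is compound 4 `C[C@H](NC(=O)c1ccccn1)c1ccc(NC(=O)[C@H]2C[C@@H]2c2cccnc2)cc1`. It carries pyridin-2-yl in place of 2,2,2-trifluoroethyl on a carbonyl carbon whose other neighbour is the amide-type nitrogen (pyridin-2-yl in place of 2,2,2-trifluoroethyl on a carbonyl carbon). For the measured compounds named here, no measured pair of compounds shows a change of this kind, so the expectation starts from compound 3 at 5 nM and stays cautious. A slight weakening in this assay is expected, with no shift beyond the usual scatter. The expected change is a 1.6-fold higher number from compound 3 to compound 4 (0.20 log units; within the scatter). Compound 4 is estimated at 8 nM, with an expected range from 2 nM to 40 nM.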

Compound 4, half-maximal inhibitory concentration: 14 nM
Compound 4: middle estimate off by 1.8-fold (0.24 log units), on the low side, within the range that was stated.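

In this assay, among the compounds shown here, the carbonyl carbon whose other neighbour is the amide-type nitrogen now has two measured substituents for the first time, and replacing 2,2,2-trifluoroethyl with pyridin-2-yl gives a 2.8-fold higher number from compound 3 to compound 4 (0.45 log units; beyond the scatter) as a real but modest loss. The place therefore accepts a six-membered aromatic ring in exchange for an open chain, and compound 4 still gives 14 nM in this assay as a clear inhibitor of cell growth. Nothing given here explains why the number rises with this change.

The compounds shown leave open whether the ring nitrogen of pyridin-2-yl contributes, which a plain phenyl ring at the same place would address. They also leave open how an amine, a carboxylic acid or a longer chain would fare on this carbonyl carbon.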